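This account rests on a few compounds, and the source may have more. Where it says the series, first, only, none or still open, it means among the compounds named here.

Measured in an ADME assay on HEK-293T cells (Homo sapiens) for cytotoxicity, read by CCK-8 assay, with a stated time of 48 h; on this read-out higher numbers stand for weaker inhibition and lower numbers for stronger inhibition:
- compound 1 `COc1ccc(Oc2ccc(C(C)C)cc2-c2ccsc2S(=O)(=O)NCCNC(=S)Nc2ccc([N+](=O)[O-])cc2)cc1OC`: 11400 nM
- compound 2 `O=C(Nc1cccc([N+](=O)[O-])c1)N1CCN(S(=O)(=O)c2sccc2-c2ccccc2Oc2ccc(O)c(O)c2)CC1`: > 20000 nM (a limit)
- compound 3 `COc1ccc(NC(=O)NCCNS(=O)(=O)c2sccc2-c2ccc(C)cc2Oc2ccc(O)c(O)c2)cc1`: > 20000 nM (a limit)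

Compound 3 has no number in this assay, only the limit > 20000 nM. It sits with compound 2 at the limit of > 20000 nM in this assay, at which 2 of the 3 values shown sit. Compound 1 is the only one of the three with a number, at 11400 nM.

The next compound is compound 4 `COc1ccc(NC(=S)NCCNS(=O)(=O)c2sccc2-c2ccc(C)cc2Oc2ccc(O)c(O)c2)cc1`, not yet measured. It replaces the (4-methoxyphenyl)carbamoyl of compound 3 on an amine nitrogen whose other neighbour is a saturated chain carbon: a group of 11 heavy atoms (8 carbon, 1 nitrogen, 1 oxygen, 1 sulfur; one six-membered aromatic ring of carbon only) in place of a group of 11 heavy atoms (8 carbon, 1 nitrogen, 2 oxygen; one six-membered aromatic ring of carbon only), on an amine nitrogen. The entering group holds sulfur where the leaving group holds its second oxygen, and the rest of the count is unchanged.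

Among the compounds with values here, no measured pair isolates this change. Within the data shown here, the only guide is compound 1, which also has sulfur in place of that oxygen and gives 11400 nM, though it differs from compound 4 elsewhere as well. A small shift toward stronger inhibition is therefore expected, perhaps not beyond the scatter, and a result at the limit remains quite possible. The expected step is an at least 1.2-fold lower number from compound 3 to compound 4 (0.09 log units; that floor lies within the scatter). For compound 4 the estimate is 16000 nM, with an expected range from 8000 nM to 30000 nM.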

Compound 4, half-maximal inhibitory concentration: > 20000 nM
Compound 4: a limit, no number; the forecaster's own chance of this, stated with the estimate: 40%; at least 1.2-fold (0.09 log units) between middle value and limit.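

Compound 3 and compound 4 both give only a limit in this assay, so no step can be read from one to the other: the limit of > 20000 nM in this assay, at which 3 of the 4 values shown sit.

The compounds shown leave open whether sulfur in place of the second oxygen changes this read-out at all, and how far compound 3 and compound 4 lie beyond their limits.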